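The compounds below may be only part of what the source reports. "The series", "measured", "known", "first", "only" and "open" are said of these compounds alone.

Measured so far:
- compound 1, `CC(C)S(=O)(=O)N1CCN(c2cnn(-c3cccc(Cl)c3)c(=O)c2OC2CCCC2)CC1`: 490 ng.h/mL
- compound 2, `CC(C)S(=O)(=O)N1CCN(c2cnn(-c3ccccc3)c(=O)c2OC2CCCC2)CC1`: 1600 ng.h/mL

Both were run in an ADME assay on the whole organism for pharmacokinetics, with Rattus norvegicus as the target, with a stated time of 6 h, at a dose of 10 mg/kg by the oral route; on this read-out higher numbers stand for higher exposure at the dose given and lower numbers for lower exposure. Compound 2, the one with a plain phenyl on the ring nitrogen, gives the higher of the two numbers; its nearest neighbour is compound 1, whose number is lower by a 3.3-fold higher number from compound 1 to compound 2 (0.51 log units; beyond the scatter), a modest gap that is nonetheless beyond the scatter.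

The unmeasured compound 3, `CC(C)S(=O)(=O)N1CCN(c2cnn(-c3cc(F)cc(Cl)c3)c(=O)c2OC2CCCC2)CC1`, returns to the pattern of compound 1 and adds a second halogen: 3-chloro-5-fluorophenyl in place of phenyl on an aromatic nitrogen. Among the measured compounds shown here, the only measured step that bears on this change is the one between compound 1 and compound 2, where removing a single chloro raised exposure by a 3.3-fold higher number from compound 1 to compound 2 (0.51 log units; beyond the scatter). Putting that chloro back is therefore expected to cost roughly that much, and the added fluoro has no comparison here to guide it. The expectation for compound 3 is a drop in this assay of about a 4.0-fold lower number from compound 2 to compound 3 (0.60 log units; beyond the scatter) relative to compound 2, landing at or somewhat under compound 1. Compound 3 is estimated at 400 ng.h/mL, with a range from 130 ng.h/mL to 1200 ng.h/mL.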

Compound 3, area under the concentration-time curve: 490 ng.h/mL
The estimate for compound 3 lay 1.2-fold (0.09 log units) below the measured number; the measured number falls inside the stated range.
By their numbers in this assay, from the lowest: compounds 1 and 3 (each within the scatter of the next); then compound 2.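

In this assay, replacing phenyl with 3-chloro-5-fluorophenyl on the aromatic nitrogen gives a 3.3-fold lower number from compound 2 to compound 3 (0.51 log units; beyond the scatter) for the full swap, a step of the same size as the one seen earlier with the chloro alone, a 3.3-fold higher number from compound 1 to compound 2 (0.51 log units; beyond the scatter) in the opposite direction. Fluoro in place of hydrogen on the chlorinated ring gives no change at the digits printed from compound 1 to compound 3 (within the scatter) at this dose, so across these three compounds the higher exposure goes with the plain phenyl, and both chloro-bearing rings sit together at the lower level whether or not the fluoro is present. Exposure is a single overall number, and nothing available here explains why the chloro step matters while the fluoro step does not.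

Still open, from the compounds shown here alone, is whether fluoro on its own, on a phenyl with no chloro, would leave exposure close to that of compound 2 or lower it as the chloro does. Equally open, going by these compounds, is how other groups at that spot on the phenyl ring, such as a methoxy, a nitrile or an amine, would compare with the chloro.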